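This account rests on a few compounds, and the source may have more. Where it says the series, first, only, none or still open, it means among the compounds named here.

In a functional assay on A549 cells (Homo sapiens) for antiproliferative activity, read by MTT assay, with a stated time of 72 h (on this read-out higher numbers stand for weaker inhibition and lower numbers for stronger inhibition), compound 1 (`Cc1ccc(S(=O)(=O)NC(=N)N2CCN(c3cc4c(cc3F)c(=O)c(C(=O)O)cn4C3CC3)CC2)cc1`) gives 71 nM, and compound 2 (`N=C(NS(=O)(=O)c1ccc(C(F)(F)F)cc1)N1CCN(c2cc3c(cc2F)c(=O)c(C(=O)O)cn3C2CC2)CC1`) gives 71 nM, so compound 2 stands level with compound 1 on the numbers available. Compound 3 (`N=C(NS(=O)(=O)c1ccc(Cl)cc1)N1CCN(c2cc3c(cc2F)c(=O)c(C(=O)O)cn3C2CC2)CC1`) shares the core of compound 2 but has chloro in place of trifluoromethyl on an aromatic carbon, para to a large group: chloro in place of trifluoromethyl on an aromatic carbon. Going by the values given here, one measured step bears on this exchange, namely no change at the digits printed from compound 1 to compound 2 (within the scatter), where trifluoromethyl took the place of methyl on an aromatic carbon. That single step is small, but it offers only limited guidance for a chloro group, which has not yet been tested in this series. No shift beyond the scatter is therefore expected in this assay, and the estimated step is a 1.0-fold lower number from compound 2 to compound 3 (0.01 log units; within the scatter). For compound 3 the estimated value is 70 nM, with an expected range of 30 nM to 170 nM.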

Compound 3, half-maximal inhibitory concentration: 71 nM
Compound 3: the middle estimate sits 1.0-fold (0.01 log units) below what was measured, and the stated range covers the measured number.
By their numbers in this assay, from the lowest: compounds 1, 2 and 3 (each within the scatter of the next).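

In this assay, the exchange of trifluoromethyl for chloro on this aromatic carbon, para to a large group, gives no change at the digits printed from compound 2 to compound 3 (within the scatter) even though four heavy atoms give way to one. The step from methyl reads the same, with no change at the digits printed from compound 1 to compound 3 (within the scatter) in the same assay, so this position has now carried three different groups with nothing beyond the scatter to separate them, and chloro joins methyl and trifluoromethyl at this place on the shared core. No measurement of any property of these groups is available to account for this result. The compounds shown leave open whether an amine, a carboxylic acid or a longer chain at this position would also stay within the scatter of these three. They also leave open how a bare hydrogen would read here.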